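Pyrazolyl in Place of Phenyl on a Shared Amide Core

The source may report more compounds than this note shows. Statements on the series, on what has been measured and on what is new or still open speak of the compounds shown alone.

Three compounds share one core. In a functional assay on MV4-11 cells (Homo sapiens) for antiproliferative activity, with a stated time of 6 days, tested at 6.25 uM (on this read-out higher numbers stand for a stronger effect at the one concentration tested and lower numbers for a weaker effect), compound 1 `CNC(=O)N1CCCc2ccc(NC(=O)c3cccc(-c4ccccc4)c3)cc21` gives 1.39%, the lowest of the three numbers; compound 2 `CNC(=O)N1CCCc2ccc(NC(=O)c3ccc(-c4ccn(C)n4)cc3)cc21` gives 97% and compound 3 `CNC(=O)N1CCCc2ccc(NC(=O)c3ccc(-c4cnn(S(C)(=O)=O)c4)cc3)cc21` gives 40.2%, both beyond the scatter above compound 1. Among the compounds with values here, the only step between measured neighbours, a number 56.8 percentage points lower from compound 2 to compound 3 (beyond the scatter), shows how much the substituted pyrazole itself can shift this assay. Compound 4 `CNC(=O)N1CCCc2ccc(NC(=O)c3cccc(-c4cc[nH]n4)c3)cc21` differs from compound 1 by 1H-pyrazol-3-yl in place of phenyl on an aromatic carbon. Within the data shown here, no measured step matches this change exactly, yet compounds 2 and 3, each carrying a substituted pyrazole, stand far above compound 1, so a rise beyond the scatter is expected, with wide uncertainty. The estimate for compound 4 is 55%, with a range from 10% to 95%. The expected change is a number 53.6 percentage points higher from compound 1 to compound 4 (beyond the scatter).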

Compound 4, a percentage reported as inhibition, at one concentration (the size of the read-out at that concentration, not a potency): 89.7%
Compound 4: middle estimate off by 34.7 percentage points, on the low side, and the stated range covers the measured number.
By their numbers in this assay, from the lowest: compound 1; then compound 3; then compounds 4 and 2 (each within the scatter of the next).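

Replacing phenyl with 1H-pyrazol-3-yl on the aromatic carbon meta to a large group, with nothing else altered, gives a number 88.3 percentage points higher from compound 1 to compound 4 (beyond the scatter) in this assay. Within the data shown here, this is the first direct reading of the ring change at this position, since compounds 2 and 3 differ from compound 1 in more than one place. No measurement here accounts for the size of this step. From the compounds shown here alone, whether a pyridyl or imidazolyl ring at this position would give a similar number remains open. So does the effect of adding a methyl group to the pyrazole nitrogen of compound 4.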